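Swapping a Phenyl Tail for a Nonyl Chain

The source may hold more compounds than are shown below. What is called first, only, known or untested is meant among the compounds shown, and "the series" means these compounds.

In an assay on microsomes from intestine for inhibition of acyl-CoA:cholesterol acyltransferase (Oryctolagus cuniculus) (a lower number here means a stronger inhibitor, a higher number a weaker inhibitor), the three measured compounds give:
compound 1 `CC(C)c1cccc(C(C)C)c1OC(=O)NC(=O)SCc1ccc(Cl)cc1`: 160 nM
compound 2 `CC(C)c1cccc(C(C)C)c1OC(=O)NC(=O)SCCCc1ccccc1`: 69 nM
compound 3 `CC(C)c1cccc(C(C)C)c1OC(=O)NC(=O)SC1CCCCC1`: 97 nM

Compound 2 has the lowest number of the three. Its step to compound 3 is a 1.4-fold higher number from compound 2 to compound 3 (0.15 log units; within the scatter), so the two cannot be told apart, while the step of a 2.3-fold lower number from compound 1 to compound 2 (0.37 log units; beyond the scatter) is a real if modest gain.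

Compound 4 `CCCCCCCCCCCCSC(=O)NC(=O)Oc1c(C(C)C)cccc1C(C)C` differs from compound 2 in one place: nonyl in place of phenyl on a saturated chain carbon, three bonds along the chain from a sulfur. Among the compounds with values here, two measured steps touch on what hangs from the sulfur. The step of a 2.3-fold lower number from compound 1 to compound 2 (0.37 log units; beyond the scatter) shows that a longer, flexible attachment with a phenyl at its end lowers the number modestly; the step of a 1.4-fold higher number from compound 2 to compound 3 (0.15 log units; within the scatter) shows that a saturated ring in place of that attachment leaves the number within the scatter. Within the data shown here, no measured compound carries a long unbranched chain without any ring, so the expectation for compound 4 rests on a loose reading of these steps: a step that stays within the scatter, with a wide range to either side. For compound 4 in this assay the estimated value is 80 nM, between 30 nM and 250 nM, which means an expected step of a 1.2-fold higher number from compound 2 to compound 4 (0.06 log units; within the scatter).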

Compound 4, half-maximal inhibitory concentration: 16 nM
Compound 4: the middle estimate sits 5.0-fold (0.70 log units) above what was measured; the measured number lies below the stated range.
By their numbers in this assay, from the lowest: compound 4; then compounds 2, 3 and 1 (each within the scatter of the next, the first and the last beyond it).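

The change from phenyl to nonyl on a saturated chain carbon, three bonds along the chain from a sulfur, gives a 4.3-fold lower number from compound 2 to compound 4 (0.63 log units; beyond the scatter) in this assay and shows that a ring at the end of this attachment is not needed for a low number. The other compounds showed only steps that were modest or within the scatter, and none of them carried a long unbranched chain, so this open chain reveals more room for gain at this position than they suggested. No measured evidence on hand explains the gain.

On these data alone, it remains open whether a shorter chain such as butyl, a longer one such as dodecyl, or a branched chain on the same carbon would lower the number further. As far as these compounds go, it is also open how an amine or a carboxylic acid at the chain's far end would change the number.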